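Series notes: chloro to trifluoromethyl

The source may report more compounds than this note shows. Statements on the series, on what has been measured and on what is new or still open speak of the compounds shown alone.

- compound 1 `CC1(C)Oc2ccc(C#N)cc2[C@@H](/N=C(\NC#N)Nc2ccc(Cl)cc2)[C@@H]1O` gives 1800 nM 
- compound 2 `CC1(C)Oc2ccc(C#N)cc2[C@@H](NC(=O)Nc2cccnc2)[C@@H]1O` gives 500 nM 

In a functional assay (aorta) with Rattus norvegicus as the target (a higher number here means a weaker inhibitor, a lower number a stronger inhibitor), compound 1 stands at 1800 nM as the higher of the two numbers, with compound 2 lower by more than the scatter. Compound 3 `CC1(C)Oc2ccc(C#N)cc2[C@@H](/N=C(\NC#N)Nc2ccc(C(F)(F)F)cc2)[C@@H]1O` differs from compound 1 by one change trifluoromethyl in place of chloro on an aromatic carbon with trifluoromethyl in place of chloro on an aromatic carbon, para to a large group. Among the compounds with values here, no measured step covers this change. The expected move in this assay is a 1.2-fold lower number from compound 1 to compound 3 (0.08 log units; within the scatter) and stays within the scatter. For compound 3 the estimated value is 1500 nM with an expected range of 500 nM to 4500 nM for now.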

Compound 3, half-maximal inhibitory concentration: 8100 nM
Estimate against measurement, compound 3: 5.4-fold (0.73 log units) below, and the stated range ends below it.
By their numbers in this assay, from the lowest: compound 2; then compound 1; then compound 3.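

In this assay this place on the aromatic ring is not indifferent to the substituent: trifluoromethyl in place of chloro gives a 4.5-fold higher number from compound 1 to compound 3 (0.65 log units; beyond the scatter). Of the two groups tested here, chloro goes with the lower number, so the larger trifluoromethyl is not tolerated as an equal replacement on this scaffold. No measured property of either compound accounts for the step.

Still open, from the compounds shown here alone, is how fluoro, methoxy or an amine would read at this place. A single pair also leaves open whether the step holds on any other core.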